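The compounds below may be only part of what the source reports. "The series", "measured", "known", "first", "only" and "open" are said of these compounds alone.

Three compounds that share one core have been taken into a physicochemical assay for lipophilicity, using the shake flask method, in phosphate buffer, measured as octanol-water partition, with a stated time of 24 h, at pH 7.4, tested at 100 uM; on this read-out lower numbers stand for lower lipophilicity and higher numbers for higher lipophilicity: compound 1 `Cc1cccc(C)c1-c1cccc(COc2ccc(S(=O)(=O)CC(=O)O)cc2)c1`, compound 2 `Cc1ccccc1-c1cccc(COc2ccc(S(=O)(=O)CC(=O)O)cc2)c1` and compound 3 `N#Cc1ccccc1-c1cccc(COc2ccc(S(=O)(=O)CC(=O)O)cc2)c1`. In this assay compound 1 gives 2.49, and compound 2 gives 2.35. For compound 3 the result reads "not determined" (no result reported), so it has no place on this scale and offers no number to start from.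

The next structure, compound 4 `CCOc1ccc(-c2cccc(COc3ccc(S(=O)(=O)CC(=O)O)cc3)c2)c(Cl)c1`, differs from compound 3 by having 2-chloro-4-ethoxyphenyl in place of 2-cyanophenyl on an aromatic carbon.

Going by the values given here, only one measured step is available, and it shows a number 0.14 log units lower from compound 1 to compound 2 (within the scatter), with hydrogen in place of methyl on an aromatic carbon. That step involves neither of the groups exchanged here, so it bears on this change only weakly. Among the compounds with values here, with no number for compound 3, no step from it can be sized, and the values of compounds 1 and 2 become the nearest anchor. Within the data shown here, a number modestly higher than those two values is expected, but this is a judgement based on the larger entering group, and no measured step demonstrates it.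

For compound 4 the estimated value is 2.9, with an expected range from 2.4 to 3.4.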

Compound 4, distribution coefficient: 3.12
Compound 4: the middle estimate sits 0.22 log units below what was measured, within the range that was stated.
By their numbers in this assay, from the lowest: compounds 2 and 1 (each within the scatter of the next); then compound 4.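

In this assay, going by these compounds alone, the 2-chloro-4-ethoxyphenyl group gives a number 0.77 log units higher from compound 2 to compound 4 (beyond the scatter) when it replaces 2-methylphenyl and a number 0.63 log units higher from compound 1 to compound 4 (beyond the scatter) when it replaces 2,6-dimethylphenyl, and these are the first steps at this aromatic carbon to pass the usual scatter. Within the data shown here, the only earlier step that could be read, a number 0.14 log units lower from compound 1 to compound 2 (within the scatter) with hydrogen in place of methyl, did not pass it, so the read-out now shows that exchanging the whole group at this place can shift the number by more than repeat measurements would. The step from compound 3 cannot be read, and no measurement shown offers an explanation for the rise in compound 4.

On these data alone, the entering group differs from both 2-methylphenyl and 2,6-dimethylphenyl in more than one feature, so it remains open whether the chlorine, the ethoxy chain or the two together account for the higher number. As far as these compounds go, how the number would respond to a longer chain such as butoxy, or to an amine on this ring, also remains open.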